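Swapping the aryl cap on the triazole of compound 1

The source may report more compounds than this note shows. Statements on the series, on what has been measured and on what is new or still open speak of the compounds shown alone.

For the measured compounds named here, compound 1 `CCOC(=O)C1=Cc2ccccc2OC1(OCc1cn(-c2ccc(F)cc2)nn1)C(F)(F)F` gives 7300 nM in a functional assay on A549 cells (Homo sapiens) for inhibition, read by MTT assay, with a stated time of 24 h (a lower number here means a stronger inhibitor, a higher number a weaker inhibitor), and stands lowest of the two compounds measured so far. Compound 2 `COc1ccc(-c2cc(COC3(C(F)(F)F)Oc4ccccc4C=C3C(=O)O)on2)cc1` gives 36200 nM in this assay, a higher number than compound 1. Compound 3 `CCOC(=O)C1=Cc2ccccc2OC1(OCc1cn(CC(=O)Nc2ccc(OC)cc2)nn1)C(F)(F)F` has not yet been measured; it differs from compound 1 by ((4-methoxyphenyl)carbamoyl)methyl in place of 4-fluorophenyl on an aromatic nitrogen. Going by the values given here, no step between measured compounds tells how such a change acts, so he expects only a modest shift, from compound 1 to compound 3 of a 1.4-fold higher number from compound 1 to compound 3 (0.14 log units; within the scatter), within or a little beyond the scatter. For compound 3 he estimates 10000 nM, with a range of 3000 nM to 40000 nM.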

Compound 3, half-maximal inhibitory concentration: 29400 nM
Compound 3: the middle estimate sits 2.9-fold (0.47 log units) below what was measured; measured number inside the range.
By their numbers in this assay, from the lowest: compound 1; then compounds 3 and 2 (each within the scatter of the next).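

This position on an aromatic nitrogen is sensitive to what it carries: in this assay, ((4-methoxyphenyl)carbamoyl)methyl in place of 4-fluorophenyl gives a 4.0-fold higher number from compound 1 to compound 3 (0.61 log units; beyond the scatter). The entering group keeps a six-membered aromatic ring and adds a hydrogen-bond donor and acceptors, yet this single change gives no lower number. As far as these compounds go, whether the amide link or the 4-methoxyphenyl end drives the step remains open, as does how an amine or a carboxylic acid at this position would read. No available evidence accounts for the step.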